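Shortening the Link to a Hydantoin Ring

This account rests on a few compounds, and the source may have more. Where it says the series, first, only, none or still open, it means among the compounds named here.

Three compounds built on one shared core have been run in an ADME assay on microsomes from liver (Rattus norvegicus) for metabolic stability; a higher number here means that the compound lasts longer, a lower number that the compound disappears faster. Compound 1 `O=C1NC(=O)/C(=C/C(c2ccc(-c3ccc4cccc(F)c4c3)[nH]c2=O)C2CC2)O1` is described only by a limit, the limit of > 3 h in this assay, at which 1 of the 3 values shown sits: in this assay compound 1 gives > 3 h, which is a limit of the assay and not a number. Compound 2 `CC(C)[C@@H](c1ccc(-c2ccc3cccc(F)c3c2)[nH]c1=O)[C@H]1OC(=O)NC1=O` gives 1.93 h in this assay. Compound 3 `CC(C)C(CC1NC(=O)NC1=O)c1ccc(-c2ccc3cccc(F)c3c2)[nH]c1=O` gives 0.35 h in this assay, the lowest of the two numbers measured, with compound 2 standing higher by a gap beyond the usual scatter.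

Compound 4 `CC(C)C(c1ccc(-c2ccc3cccc(F)c3c2)[nH]c1=O)C1NC(=O)NC1=O` has not yet been measured. It differs from compound 3 in one place: 2,5-dioxoimidazolidin-4-yl in place of (2,5-dioxoimidazolidin-4-yl)methyl on a saturated chain carbon bound to an aromatic carbon and a saturated chain carbon. The ring is thereby attached directly to the chain carbon, as the ring of compound 2 is, instead of through its methyl. For the measured compounds named here, no step between two measured compounds shows how much such a change matters here. Since compound 2 with its directly attached ring gives 1.93 h, compound 4 is expected to last longer than compound 3, with a step of a 3.4-fold higher number from compound 3 to compound 4 (0.54 log units; beyond the scatter) in this assay. Compound 4 is estimated to give about 1.2 h, within a range from 0.5 h to 3 h.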

Compound 4, half-life: 0.145 h
Estimate against measurement, compound 4: 8.3-fold (0.92 log units) above, and the stated range ends above it.
By their numbers in this assay, from the lowest: compound 4; then compound 3; then compound 2. At a limit, above all of these: compound 1.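

In this assay, taking out the methyl link so that the 2,5-dioxoimidazolidin-4-yl ring sits directly on the chain carbon gives a 2.4-fold lower number from compound 3 to compound 4 (0.38 log units; beyond the scatter) and so goes with faster disappearance, the opposite of what the directly attached ring of compound 2 suggested. Direct attachment alone therefore does not carry the longer half-life, since compound 2 gives 1.93 h with a different ring on the same kind of link, while compound 4 gives 0.145 h with the 2,5-dioxoimidazolidin-4-yl ring. Nothing measured here bears on the reason for this step.

As far as these compounds go, whether a longer chain, such as an ethyl link to the same ring, would raise or lower the half-life stays open. So does the effect of an amine or a carboxylic acid in place of the ring.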